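The source may hold more compounds than are shown below. What is called first, only, known or untested is meant among the compounds shown, and "the series" means these compounds.

In a functional assay on MGC-803 cells (Homo sapiens) for inhibition, read by MTT assay, with a stated time of 72 h (a higher number here means a weaker inhibitor, a lower number a stronger inhibitor), three compounds that share one core have been measured. Compound 1 `C#CCSc1nc(NCCC#N)c2ccncc2n1` carries 2-cyanoethyl on a nitrogen on an aromatic ring and gives > 80000 nM as a limit of the assay and not a number. Compound 2 `C#CCSc1nc(Nc2cccc(Cl)c2)c2ccncc2n1` carries 3-chlorophenyl at that place and gives 2190 nM as its result, while compound 3 `C#CCSc1nc(Nc2ccccc2O)c2ccncc2n1` carries 2-hydroxyphenyl and gives 21000 nM as the higher of the two true numbers, which makes it the weaker inhibitor of that pair.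

Compound 4 `C#CCSc1nc(Nc2ccc(O)cc2)c2ccncc2n1` differs from compound 3 by one change: 4-hydroxyphenyl in place of 2-hydroxyphenyl on a nitrogen on an aromatic ring and the two have the same atoms, joined differently. Three measured steps swap the group at this place. They are an at least 36-fold lower number from compound 1 to compound 2 (1.56 log units; beyond the scatter) and an at least 3.8-fold lower number from compound 1 to compound 3 (0.58 log units; beyond the scatter) and the closest guide a 9.6-fold higher number from compound 2 to compound 3 (0.98 log units; beyond the scatter) between the two phenyl-bearing compounds. Among the compounds with values here, no measured step swaps one hydroxyphenyl group for another, so this guide is indirect.

A modest step to a lower number is expected in this assay and the lean rests only on compound 2 at 2190 nM as the stronger phenyl-bearing neighbour. The expected step is a 2.3-fold lower number from compound 3 to compound 4 (0.37 log units; beyond the scatter) and it is uncertain. For compound 4 the estimated value is 9000 nM with an expected range from 2500 nM to 35000 nM in this estimate.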

Compound 4, half-maximal inhibitory concentration: > 80000 nM
Compound 4: a limit, no number; the forecaster's own chance of this, stated with the estimate: 8%; at least 8.8-fold (0.94 log units) between middle value and limit.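

In this assay compound 4 gives > 80000 nM as a limit of the assay and not a number. Replacing 2-hydroxyphenyl with 4-hydroxyphenyl on the nitrogen keeps the same atoms but joins them differently, yet it gives an at least 3.8-fold higher number from compound 3 to compound 4 (0.58 log units; beyond the scatter) and so shows that at this place the arrangement of the group matters, not only the atoms it contains. The comparison with 3-chlorophenyl gives an at least 36-fold higher number from compound 2 to compound 4 (1.56 log units; beyond the scatter) and shows that a phenyl ring on this nitrogen does not by itself bring a low number, as compound 4 goes against any such rule while compound 2 and compound 3 read lower.

The step between compound 1 and compound 4 cannot be read, because both end at the same limit: the limit of > 80000 nM in this assay, at which 2 of the 4 values shown sit. Still open, as far as these compounds go, is how a 3-hydroxyphenyl, a 4-methoxyphenyl, a 4-aminophenyl or a plain phenyl group would read at this place, and so whether the drop seen with 4-hydroxyphenyl belongs to the hydroxyl group alone or to any group placed as it is there.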